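The compounds below may be only part of what the source reports. "The series", "measured", "known", "first", "only" and "open" are said of these compounds alone.

Compound 1 `CCOC(=O)C1(Cc2ccccc2)CN(c2ccccc2)Cc2nnn(Cc3ccccc3Cl)c21` gives > 100000 nM in an ADME assay on HEL cells (Homo sapiens) for cytotoxicity, read by microscopy, with a stated time of 3 days (on this read-out lower numbers stand for higher toxicity in this test and higher numbers for lower toxicity in this test), which is a limit of the assay.
Compound 2 `CCOC(=O)C1(Cc2ccccc2)CN(c2ccccc2)Cc2nnn(Cc3ccc(Cl)c(Cl)c3)c21` gives > 100000 nM in this assay, again a limit of the assay.
Compound 3 `CCOC(=O)C1(Cc2ccccc2)CN(c2ccccc2)Cc2nnn(Cc3c(F)cccc3Cl)c21` gives > 100000 nM in this assay, also a limit of the assay.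

The three compounds share one core and differ only in the benzyl group. From compound 1 to compound 2 the change is 3,4-dichlorophenyl in place of 2-chlorophenyl on a saturated chain carbon bound to an aromatic nitrogen. From compound 1 to compound 3 the change is fluoro in place of hydrogen on an aromatic carbon, and it gave a step that the two limits leave unreadable from compound 1 to compound 3. The unmeasured compound 4 `CCOC(=O)C1(Cc2ccc(F)cc2)CN(c2ccccc2)Cc2nnn(Cc3ccc(Cl)c(Cl)c3)c21` arises from compound 2 by fluoro in place of hydrogen on an aromatic carbon. This is the same kind of change, but the surroundings differ: in compound 4 the fluoro enters para to a large group, whereas in compound 3 it sits ortho to a large group and meta to a chloro group. The step is expected to be a number no higher from compound 2 to compound 4 (the limit leaves the size open), resting on a step that the two limits leave unreadable from compound 1 to compound 3 and on (the limit of > 100000 nM in this assay, at which 3 of the 3 values shown sit). Compound 4 is therefore estimated at 100000 nM, most likely reported once more as a limit.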

Compound 4, minimum cytotoxic concentration: > 100000 nM
Compound 4: only a limit was reported; the forecaster's own chance of this, stated with the estimate: 85%; the middle value sits exactly at the limit.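

Compound 2 and compound 4 both stand at a limit of the assay, so no size can be read for the step between them: the limit of > 100000 nM in this assay, at which 4 of the 4 values shown sit. The compounds shown leave open at what concentration any of them would harm these cells.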